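This account rests on a few compounds, and the source may have more. Where it says the series, first, only, none or still open, it means among the compounds named here.

Measured in a physicochemical assay for lipophilicity, using the shake flask method; on this read-out lower numbers stand for lower lipophilicity and higher numbers for higher lipophilicity:
- compound 1 `C[C@H](Oc1cc2cc(C(N)=O)ccc2nc1N)c1cc2c(cnn2CCO)cc1-n1cccn1`: 2.1
- compound 2 `C[C@H](Oc1cc2cc(C(N)=O)ccc2nc1N)c1cc2[nH]ncc2cc1-n1cccn1`: 2.7

Compound 1 stands lowest of the two, with 2.1 in this assay. Compound 3 `C[C@H](Oc1cc2cc(F)ccc2nc1N)c1cc2c(cnn2CCO)cc1-n1cccn1` keeps the 2-hydroxyethyl of compound 1 but carries fluoro in place of carbamoyl on an aromatic carbon. For the measured compounds named here, only one measured step is available, a number 0.60 log units higher from compound 1 to compound 2 (beyond the scatter), with hydrogen in place of 2-hydroxyethyl on an aromatic nitrogen. Going by the values given here, it is modest and lies at a different place, so it bears on this change only loosely, and no measured pair shows a change at the carbamoyl itself. A higher number is nevertheless expected here, in a step somewhat larger than that one. The estimated step is a number 1.10 log units higher from compound 1 to compound 3 (beyond the scatter). For compound 3 the expected value is 3.2, with an estimated range of 2.7 to 3.7.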

Compound 3, distribution coefficient: 3.3
Compound 3: middle estimate off by 0.10 log units, on the low side, within the range that was stated.
By their numbers in this assay, from the lowest: compound 1; then compound 2; then compound 3.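

In this assay, the exchange of carbamoyl for fluoro gives a number 1.20 log units higher from compound 1 to compound 3 (beyond the scatter) and is a large step, whereas a number 0.60 log units higher from compound 1 to compound 2 (beyond the scatter) at the aromatic nitrogen is a modest one. The read-out therefore responds to a change on this aromatic carbon of the six-membered carbon ring as well as to a change at the aromatic nitrogen. With 2-hydroxyethyl kept in place, this single change moves compound 3 to the top of the three compounds. Nothing available accounts for the size of this step.

Going by these compounds, whether fluoro gives a similar step when hydrogen sits on the aromatic nitrogen, as in compound 2, remains open. So does how a nitrile, a primary amine or a carboxylic acid on this aromatic carbon would compare with carbamoyl and fluoro.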